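This account rests on a few compounds, and the source may have more. Where it says the series, first, only, none or still open, it means among the compounds named here.

Compound 2, with the structure `Cc1cc(C)c(Oc2cc(Nc3ccc(C#N)cc3)ncc2C(=O)NCc2cn(Cc3ccc([N+](=O)[O-])cc3)nn2)c(C)c1`, stands only at a limit in an ADME assay on MT4 cells (Homo sapiens) for cytotoxicity, read by MTT assay, with a stated time of 5 days; a higher number here means that more compound is tolerated, a lower number that less compound is tolerated. In this assay compound 2 gives >= 139000 nM, which is a limit of the assay and not a number. Compound 1, with the structure `Cc1cc(C)c(Oc2cc(Nc3ccc(C#N)cc3)ncc2C(=O)NCc2cn(Cc3ccccc3F)nn2)c(C)c1`, gives > 222000 nM in this assay, likewise a limit. The step that the two limits leave unreadable from compound 1 to compound 2 therefore cannot be read in size or direction. Compound 3, with the structure `Cc1cc(C)c(Oc2cc(Nc3ccc(C#N)cc3)ncc2C(=O)NCc2cn(CC(=O)N3CCCC3)nn2)c(C)c1`, differs from compound 2 by (pyrrolidin-1-yl)carbonyl in place of 4-nitrophenyl on a saturated chain carbon bound to an aromatic nitrogen. No readable measured step bears on this change, since both known values sit at limits (the limit of > 222000 nM in this assay, at which 1 of the 2 values shown sits, (the limit of >= 139000 nM in this assay, at which 1 of the 2 values shown sits)). The step that the limit leaves unreadable from compound 2 to compound 3 is expected to lie within the scatter. Compound 3 is estimated at 200000 nM, within 100000 nM to 400000 nM.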

Compound 3, half-maximal cytotoxic concentration: 58100 nM
For compound 3 the middle estimate is 3.4-fold (0.54 log units) above the measured one; measured number below the stated range.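

In this assay, compound 3 gives the first number at this position that is not a limit, so the place on a saturated chain carbon bound to an aromatic nitrogen is shown to affect the result. Replacing 4-nitrophenyl with (pyrrolidin-1-yl)carbonyl gives an at least 2.3-fold lower number from compound 2 to compound 3 (0.37 log units; beyond the scatter), and replacing 2-fluorophenyl with the same group gives an at least 3.8-fold lower number from compound 1 to compound 3 (0.58 log units; beyond the scatter). The step between the two aromatic groups still cannot be read. The compounds shown leave open whether the carbonyl or the pyrrolidine ring accounts for the lower number. They also leave open how a simple amine or a carboxylic acid would read at this place.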